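Compound 4: 3-bromophenyl in place of 4-methoxyphenyl

The compounds below may be only part of what the source reports. "The series", "measured", "known", "first", "only" and "open" are said of these compounds alone.

In a functional assay on NRK-49F cells (Rattus norvegicus) for cytotoxicity, read by MTT assay, with a stated time of 24 h (a higher number here means a weaker inhibitor, a lower number a stronger inhibitor), three compounds on the shared core have been measured. Compound 1 (`COc1ccc(/C=C(\C#N)C(=O)N/N=C(\C)c2c(O)c3ccc(O)cc3oc2=O)cc1`) gives 96100 nM, the highest of the three numbers, although only one of its two gaps lies beyond the scatter. Compound 2 (`C/C(=N\NC(=O)/C(C#N)=C/c1ccc(Br)cc1)c1c(O)c2ccc(O)cc2oc1=O`) gives 49600 nM, and compound 3 (`C/C(=N\NC(=O)/C(C#N)=C/c1cccc([N+](=O)[O-])c1)c1c(O)c2ccc(O)cc2oc1=O`) gives 46500 nM.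

The step under consideration leads to compound 4 (`C/C(=N\NC(=O)/C(C#N)=C/c1cccc(Br)c1)c1c(O)c2ccc(O)cc2oc1=O`): 3-bromophenyl in place of 4-methoxyphenyl on a double-bonded chain carbon bound to a double-bonded chain carbon. The change sits on a double-bonded chain carbon bound to a double-bonded chain carbon. Two measured steps start from the same compound and bear on it. The first, with bromo in place of methoxy on an aromatic carbon, is a 1.9-fold lower number from compound 1 to compound 2 (0.29 log units; within the scatter). The second, with 3-nitrophenyl in place of 4-methoxyphenyl, is a 2.1-fold lower number from compound 1 to compound 3 (0.32 log units; beyond the scatter). The two end points barely differ, at a 1.1-fold lower number from compound 2 to compound 3 (0.03 log units; within the scatter). Among the compounds with values here, no measured compound carries 3-bromophenyl, so that group has no direct precedent.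

A lower number than that of compound 1 is expected, close in size to those two steps and near the limit of the scatter. The expected step is a 1.9-fold lower number from compound 1 to compound 4 (0.28 log units; within the scatter). Compound 4 is estimated at 50000 nM, with an expected range of 30000 nM to 85000 nM.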

Compound 4, half-maximal inhibitory concentration: 59400 nM
Compound 4: the middle estimate sits 1.2-fold (0.07 log units) below what was measured, within the range that was stated.
By their numbers in this assay, from the lowest: compounds 3, 2, 4 and 1 (each within the scatter of the next, the first and the last beyond it).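

In this assay, 3-bromophenyl in place of 4-methoxyphenyl on a double-bonded chain carbon bound to a double-bonded chain carbon gives a step that stays within the scatter (a 1.6-fold lower number from compound 1 to compound 4 (0.21 log units; within the scatter)), whereas the step to the 3-nitrophenyl compound was printed just beyond it (a 2.1-fold lower number from compound 1 to compound 3 (0.32 log units; beyond the scatter)). Within the data shown here, the new compound also gives the first reading of where bromo sits on the phenyl ring, and 3-bromophenyl in place of 4-bromophenyl cannot be told apart in this assay (a 1.2-fold higher number from compound 2 to compound 4 (0.08 log units; within the scatter)); the same holds for bromo in place of nitro with the ring pattern kept (a 1.3-fold higher number from compound 3 to compound 4 (0.11 log units; within the scatter)), so at this position neither the placing of bromo nor the choice between bromo and nitro gives a resolved difference, and no data on hand offer a reason for these small steps.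

The compounds shown leave open whether an amine or a carboxylic acid on the phenyl ring would move the number beyond the scatter from compound 4. They also leave open what a longer chain in place of the phenyl ring would do at this position in this assay.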